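Removing the pyridine fluorine from a biaryl benzylamine inhibitor

The compounds below may be only part of what the source reports. "The series", "measured", "known", "first", "only" and "open" are said of these compounds alone.

Measured so far:
compound 1 `NCc1ccc(C(=O)Nc2ccncc2)cc1-c1cccc(C(=O)OCc2ccccc2)c1` — 45 nM
compound 2 `CCCOC(=O)c1cccc(-c2cc(C(=O)Nc3ccncc3F)ccc2CN)c1` — 5.1 nM
compound 3 `COC(=O)c1cccc(-c2cc(C(=O)Nc3ccncc3F)ccc2CN)c1` — 7.8 nM

All three were tested in an assay on isolated protein for inhibition of Rho-associated protein kinase 2 (Homo sapiens), read by radiometric assay; a lower number here means a stronger inhibitor, a higher number a weaker inhibitor. Compound 3 gives 7.8 nM, the second highest of the three numbers; its nearest neighbour is compound 2, and the step of a 1.5-fold higher number from compound 2 to compound 3 (0.18 log units; within the scatter) lies within the scatter, so the two ester sizes are not distinguishable here. Compound 1, which gives 45 nM, stands furthest away, beyond the scatter, but it differs from compound 3 in two places, the ester and the pyridine ring, so its gap cannot be assigned to either change alone.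

Compound 4 `COC(=O)c1cccc(-c2cc(C(=O)Nc3ccncc3)ccc2CN)c1` has not yet been measured in this assay. It differs from compound 3 by hydrogen in place of fluoro on an aromatic carbon. Among the compounds with values here, no measured pair isolates this change: the single measured step concerns the ester chain only and says nothing about the pyridine. Within the data shown here, the only hint is that compound 1, the one compound without the fluorine, carries the highest number; since it also carries a different ester, this hint is weak. Compound 4 is therefore expected to give a somewhat higher number, estimated at 20 nM with a range from 7 nM to 60 nM, a step of a 2.6-fold higher number from compound 3 to compound 4 (0.41 log units; beyond the scatter) that is expected to be modest and uncertain in size.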

Compound 4, half-maximal inhibitory concentration: 2.9 nM
The estimate for compound 4 lay 6.9-fold (0.84 log units) above the measured number; measured number below the stated range.
By their numbers in this assay, from the lowest: compounds 4, 2 and 3 (each within the scatter of the next, the first and the last beyond it); then compound 1.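

In this assay, within the data shown here, the change from 3-fluoropyridin-4-yl to pyridin-4-yl is isolated for the first time, and a 2.7-fold lower number from compound 3 to compound 4 (0.43 log units; beyond the scatter) shows that, with the methyl ester in place, the fluoro group on this aromatic carbon, two atoms from the ring nitrogen, is not needed for a low number, since hydrogen gives the lower one. The same ring now also stands on both sides of an ester comparison, and a 16-fold lower number from compound 1 to compound 4 (1.19 log units; beyond the scatter) ties the high number of the earlier benzyl ester to the ester itself rather than to the missing fluoro group. Nothing available explains why either change moves the number as it does.

From the compounds shown here alone, the fluoro-to-hydrogen step has been read on the methyl ester alone, so it remains open whether it would keep its direction and size with the propyl or benzyl ester. Also open, going by these compounds, is how a chloro or methyl group on the same aromatic carbon would compare with hydrogen and fluoro, and whether a carboxylic acid or an amide could stand in place of the ester.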